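Swapping a Saturated Amine Ring on a Shared Core

A few compounds are considered here, and "the series" means these few. Any claim that something is new, unique, unknown or untested is made for them only; others in the source may bear on it.

Compound 1 `O=C(/C=C/CN1CCCCC1)Nc1cc2c(N3CCc4ccccc43)ncnc2cc1O[C@@H]1CCOC1` and compound 2 `CN1CCN(C/C=C/C(=O)Nc2cc3c(N4CCc5ccccc54)ncnc3cc2O[C@@H]2CCOC2)CC1` share one core and differ only where (4-methylpiperazin-1-yl in place of piperidin-1-yl on a saturated chain carbon bound to a double-bonded chain carbon). In a functional assay on PC-3 cells (Homo sapiens) for antiproliferative activity, read by MTT assay, with a stated time of 72 h (a higher number here means a weaker inhibitor, a lower number a stronger inhibitor), compound 1 gives 4510 nM, and compound 2 gives 4210 nM; the step between them is a 1.1-fold lower number from compound 1 to compound 2 (0.03 log units; within the scatter). Compound 3 `O=C(/C=C/CN1CCCCC1)Nc1cc2c(N3CCCc4ccccc43)ncnc2cc1O[C@@H]1CCOC1` carries a different core, the difference being (1,2,3,4-tetrahydroquinolin-1-yl in place of 2,3-dihydro-1H-indol-1-yl on an aromatic carbon), and that step reads a 1.2-fold lower number from compound 1 to compound 3 (0.09 log units; within the scatter); in this assay compound 3 gives 3630 nM. Compound 4 `CN1CCN(C/C=C/C(=O)Nc2cc3c(N4CCCc5ccccc54)ncnc3cc2O[C@@H]2CCOC2)CC1` is yet to be measured; it differs from compound 3 by 4-methylpiperazin-1-yl in place of piperidin-1-yl on a saturated chain carbon bound to a double-bonded chain carbon, the same change at the same place as between the first two compounds. Resting on the earlier step of a 1.1-fold lower number from compound 1 to compound 2 (0.03 log units; within the scatter), which stayed within the scatter, the expected step here is a 1.1-fold lower number from compound 3 to compound 4 (0.03 log units; within the scatter). Compound 4 is therefore estimated at 3400 nM in this assay, between 1700 nM and 6800 nM.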

Compound 4, half-maximal inhibitory concentration: 9450 nM
Beside the measured number, compound 4's estimate is 2.8-fold (0.44 log units) below it; measured number outside the range, above it.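

In this assay the swap to 4-methylpiperazin-1-yl gave a 2.6-fold higher number from compound 3 to compound 4 (0.42 log units; beyond the scatter), so the result on the core of compound 1 did not carry over to the core of compound 3: the same change on two cores in this assay, a 1.1-fold lower number (0.03 log units; within the scatter) from compound 1 to compound 2 and a 2.6-fold higher number (0.42 log units; beyond the scatter) from compound 3 to compound 4, 2.8-fold (0.45 log units) apart, beyond the scatter of two such steps. Read the other way, the change to 1,2,3,4-tetrahydroquinolin-1-yl gave a 2.2-fold higher number from compound 2 to compound 4 (0.35 log units; beyond the scatter) with 4-methylpiperazin-1-yl in place, so the two changes do not add up independently in these compounds: the same change on two cores in this assay, a 1.2-fold lower number (0.09 log units; within the scatter) from compound 1 to compound 3 and a 2.2-fold higher number (0.35 log units; beyond the scatter) from compound 2 to compound 4, 2.8-fold (0.45 log units) apart, beyond the scatter of two such steps. This shows that the effect of the amine swap depends on the core in these four compounds, but it does not show why, and a single pair on each core cannot predict the swap on a further core.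

Going by these compounds, it remains open whether another amine on the same chain, such as morpholin-4-yl or dimethylamino, would also respond differently on the two cores.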